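Swapping a ring for two methyls on a distribution readout

This account rests on a few compounds, and the source may have more. Where it says the series, first, only, none or still open, it means among the compounds named here.

In an in vivo ADME assay on the whole organism for pharmacokinetics, with Canis familiaris (Canis lupus familiaris) as the target (a lower number here means that more of the compound stays in the plasma, a higher number that more of the compound sits outside the plasma), compound 1 `Nc1noc2ccc(-n3nc(C(F)(F)F)c4c3C(=O)N(c3ccc(-c5ccccc5CN5CCCC5)cc3)CC4)cc12` gives 5 L/kg. Among the measured compounds shown here, compound 2 `Nc1noc2ccc(-n3nc(C(F)(F)F)c4c3C(=O)N(c3ccc(-c5ccccc5CN5CC[C@@H](O)C5)cc3F)CC4)cc12` is the only other compound measured here, and in this assay compound 2 gives 2.8 L/kg; the two numbers lie within the usual scatter of each other, so the data show no real difference between them. Compound 3 `CN(C)Cc1ccccc1-c1ccc(N2CCc3c(C(F)(F)F)nn(-c4ccc5onc(N)c5c4)c3C2=O)cc1` has not yet been measured. It differs from compound 1 in one place: dimethylamino in place of pyrrolidin-1-yl on a saturated chain carbon bound to an aromatic carbon. Nothing measured here connects such a change to a shift in this assay, so a step of a 1.1-fold lower number from compound 1 to compound 3 (0.05 log units; within the scatter) is expected, which would stay inside the scatter and carry no clear direction. On that basis compound 3 is estimated to give 4.5 L/kg in this assay, with a likely range from 2.3 L/kg to 9 L/kg.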

Compound 3, volume of distribution at steady state: 4.5 L/kg
Beside the measured number, compound 3's estimate shows no gap at the digits printed, within the range that was stated.
By their numbers in this assay, from the lowest: compounds 2, 3 and 1 (each within the scatter of the next).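

Among the compounds shown here, replacing pyrrolidin-1-yl with dimethylamino gives the first comparison at this position in which only one place differs. In this assay the result is a 1.1-fold lower number from compound 1 to compound 3 (0.05 log units; within the scatter) and so shows that, between these two groups, opening the ring and removing heavy atoms leaves no difference that can be told from the scatter. No measurement here bears on why these two groups read alike.

Still open, as far as these compounds go, is whether a group less like these two at the same place, such as a morpholine ring, a primary amine or a carboxylic acid, would give a number beyond the scatter. Compound 2 differs from compound 1 in more than one place, so its number cannot be tied to any single one of those differences.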